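The source may hold more compounds than are shown below. What is called first, only, known or untested is meant among the compounds shown, and "the series" means these compounds.

Measured so far:

Compound 1 `O=C1C(NC2CCCC2)=CC(=O)c2c1nc1n2[C@H]2OC[C@@H](O)[C@H]2OC1`. In a functional assay on MCF7 cells (Homo sapiens) for inhibition, read by sulforhodamine B assay (on this read-out lower numbers stand for stronger inhibition and higher numbers for weaker inhibition), compound 1 gives only the limit > 16000 nM, not a number.
Compound 2 `CCc1ccc(NC2=CC(=O)c3nc4n(c3C2=O)[C@H]2OC[C@@H](O)[C@H]2OC4)cc1`. In this assay compound 2 gives 960 nM.
Compound 3 `COc1cccc(NC2=CC(=O)c3c(nc4n3[C@H]3OC[C@@H](O)[C@H]3OC4)C2=O)c1`. In this assay compound 3 gives 3830 nM.

Among the numbers shown, compound 2 has the lowest, and its nearest neighbour is compound 3, whose number is higher by a gap beyond the usual scatter; the third value is a limit only.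

Compound 4 `O=C1C=C(Nc2cccc(Cl)c2)C(=O)c2c1nc1n2[C@H]2OC[C@@H](O)[C@H]2OC1` is not yet measured. It differs from compound 2 in one place: 3-chlorophenyl in place of 4-ethylphenyl on an amine nitrogen.

Among the measured compounds shown here, only one measured step touches the same amine nitrogen: an at least 4.1-fold lower number from compound 1 to compound 3 (0.62 log units; beyond the scatter), which exchanged a ring of saturated carbons for an aromatic ring. Compound 1 sits at the limit (the limit of > 16000 nM in this assay, at which 1 of the 3 values shown sits), so that step is known only as a lower bound. The change from compound 2 to compound 4 keeps an aromatic ring and alters only what sits on it, so that step does not speak directly to it. That compounds 2 and 3, both aryl-bearing, differ beyond the scatter shows such ring substituents do move the number, in either direction.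

A modest step toward a higher number is therefore expected, a 1.9-fold higher number from compound 2 to compound 4 (0.27 log units; within the scatter). Compound 4 is estimated at 1800 nM, likely between 500 nM and 6000 nM.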

Compound 4, half-maximal inhibitory concentration: 4720 nM
The estimate for compound 4 lay 2.6-fold (0.42 log units) below the measured number, within the range that was stated.
By their numbers in this assay, from the lowest: compound 2; then compounds 3 and 4 (each within the scatter of the next). At a limit, above all of these: compound 1.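

Among the compounds shown here, the aromatic group on the amine nitrogen is more sensitive to change than the earlier compounds could show: in this assay, putting 3-chlorophenyl in place of 4-ethylphenyl gives a 4.9-fold higher number from compound 2 to compound 4 (0.69 log units; beyond the scatter), so keeping an aromatic ring does not by itself preserve the number. Compound 3, with 3-methoxyphenyl, and compound 4, with 3-chlorophenyl, lie within the scatter of each other, which leaves the 4-ethylphenyl group of compound 2 alone at the low end among these three aryl compounds. The data shown offer no measurement that explains this difference.

The step from 4-ethylphenyl to 3-chlorophenyl changes both the group on the ring and where it sits, so it cannot say which of the two matters; 4-chlorophenyl and 3-ethylphenyl would separate them. On these data alone, whether a longer chain in the place of the ethyl group, such as 4-propylphenyl or 4-butylphenyl, would bring the number lower or higher than in compound 2 also stays open.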